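A few compounds are considered here, and "the series" means these few. Any claim that something is new, unique, unknown or untested is made for them only; others in the source may bear on it.

Compound 1, `CC(Sc1nnc(-c2ccncc2)s1)C(=O)Nc1c(Cl)cccc1Cl`, was tested in an ADME assay on BHK-21 cells (Mesocricetus auratus) for cytotoxicity, with a stated time of 3 days; a lower number here means that less compound is tolerated, a higher number that more compound is tolerated. In this assay compound 1 gives > 50000 nM, which is a limit of the assay rather than a number; it therefore sits at the limit of > 50000 nM in this assay, at which 1 of the 2 values shown sits. A second compound, compound 2, `O=C(CSc1nnc(-c2ccncc2)s1)Nc1c(Cl)cccc1Cl`, has "not determined" (no result reported) in this assay. Compound 3, `CC(Sc1nnc(-c2ccncc2)s1)C(=O)Nc1ccc(Cl)cc1`, has not been measured yet. It differs from compound 1 in one place: 4-chlorophenyl in place of 2,6-dichlorophenyl on an amide-type nitrogen. Among the measured compounds shown here, no pair of measured compounds shows what such a change does in this assay, so the size of the step cannot be read from them. Because compound 1 sits at the limit of > 50000 nM in this assay, at which 1 of the 2 values shown sits, the step is expected to be a number no higher from compound 1 to compound 3 (the limit leaves the size open), none beyond the usual scatter. Compound 3 is thus estimated at 50000 nM, within a range from 20000 nM to 100000 nM, with a fair chance that this assay again reports only a limit.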

Compound 3, half-maximal cytotoxic concentration: > 50000 nM
Compound 3 gave a limit, no number; the forecaster's own chance of this, stated with the estimate: 65%; the middle value sits exactly at the limit.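

Compound 1 and compound 3 each give only a limit, not a number, so no step between them can be read: the limit of > 50000 nM in this assay, at which 2 of the 3 values shown sit.

The compounds shown leave open where the true values lie in this assay, and whether 4-chlorophenyl in place of 2,6-dichlorophenyl changes the result at all.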